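The compounds below may be only part of what the source reports. "The series", "measured", "known", "first", "only" and "open" are said of these compounds alone.

Working notes on a set of thio-linked nucleosides sharing one core, tested in an assay on isolated protein for binding affinity to Equilibrative nucleoside transporter 1 (Homo sapiens); on this read-out higher numbers stand for weaker inhibition and lower numbers for stronger inhibition. Compound 1 `Cc1cc(C)c(SCc2ncnc3c2ncn3[C@@H]2O[C@H](CO)[C@@H](O)[C@H]2O)c(C)c1` gives 33100 nM. Compound 2 `OC[C@H]1O[C@@H](n2cnc3c(CSc4ccccc4Br)ncnc32)[C@H](O)[C@@H]1O` gives 2400 nM. Compound 3 `OC[C@H]1O[C@@H](n2cnc3c(CSc4ccccc4I)ncnc32)[C@H](O)[C@@H]1O` gives 282 nM, the lowest of the three numbers, reached through an 8.5-fold lower number from compound 2 to compound 3 (0.93 log units; beyond the scatter) and a 120-fold lower number from compound 1 to compound 3 (2.07 log units; beyond the scatter); the step of a 14-fold lower number from compound 1 to compound 2 (1.14 log units; beyond the scatter) also runs toward lower numbers. Compound 4 `OC[C@H]1O[C@@H](n2cnc3c(CSc4ccc(I)cc4)ncnc32)[C@H](O)[C@@H]1O` is not yet measured; it differs from compound 3 in 4-iodophenyl in place of 2-iodophenyl on a sulfur. For the measured compounds named here, no measured step moves the iodine within the phenyl, so the earlier steps bear only indirectly: they show that 2-iodophenyl on the sulfur gives the lowest number seen, while 4-iodophenyl has no precedent here. A step toward a higher number is expected for compound 4, a 5.3-fold higher number from compound 3 to compound 4 (0.73 log units; beyond the scatter), with wide uncertainty. Compound 4 is estimated at 1500 nM, range 300 nM to 8000 nM.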

Compound 4, half-maximal inhibitory concentration: 69.2 nM
Compound 4: middle estimate off by 22-fold (1.34 log units), on the high side; the whole stated range lies above it.
By their numbers in this assay, from the lowest: compound 4; then compound 3; then compound 2; then compound 1.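

Moving the iodine changes the number on its own: 4-iodophenyl in place of 2-iodophenyl on the sulfur gives a 4.1-fold lower number from compound 3 to compound 4 (0.61 log units; beyond the scatter), with the atoms unchanged. Compound 4 thus takes the low end of the series from compound 3, with a 35-fold lower number from compound 2 to compound 4 (1.54 log units; beyond the scatter) and a 480-fold lower number from compound 1 to compound 4 (2.68 log units; beyond the scatter). Nothing measured here accounts for the shift. Open, going by these compounds, is whether bromo in place of iodo on the 4-iodophenyl keeps the number this low. Also open, on these data alone, is how an amine or a carboxylic acid would read there.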